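Series notes: second chloro added to the core of compound 3

The compounds below may be only part of what the source reports. "The series", "measured", "known", "first", "only" and "open" are said of these compounds alone.

Measured in a functional assay on MDA-MB-231 cells (Homo sapiens) for cytotoxicity, read by sulforhodamine B assay, with a stated time of 48 h; a higher number here means a weaker inhibitor of growth, a lower number a stronger inhibitor of growth:
- compound 1 `ClCc1cccc(Cn2cnc3c(Cl)ncnc32)c1` gives 1990 nM
- compound 2 `ClCc1ccc(Cn2cnc3nc(Cl)nc(Cl)c32)cc1` gives 1620 nM
- compound 3 `ClCc1ccccc1Cn1cnc2ncnc(Cl)c21` gives 2750 nM

Compound 3 stands at the highest of the three numbers, but its gap to compound 1 and its gap to compound 2 are both within the usual scatter, so no order among the three can be set from this assay. Within the data shown here, no pair of measured compounds differs in a single place, so no isolated step is available.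

Compound 4 `ClCc1ccccc1Cn1cnc2nc(Cl)nc(Cl)c21` differs from compound 3 by chloro in place of hydrogen on an aromatic carbon. Compound 2 already carries the additional chloro on the shared core, and in this assay compound 2 gives 1620 nM, a number that sits in the same band as compound 1 and compound 3; this offers no sign that the second chloro shifts growth inhibition beyond the scatter. The step of a 1.3-fold lower number from compound 3 to compound 4 (0.10 log units; within the scatter) is therefore expected to be none beyond the scatter. For compound 4 the expected value in this assay is 2200 nM, with a range from 900 nM to 5500 nM.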

Compound 4, concentration for 50% growth inhibition: 300 nM
For compound 4 the middle estimate is 7.3-fold (0.87 log units) above the measured one; the measured number lies below the stated range.
By their numbers in this assay, from the lowest: compound 4; then compounds 2, 1 and 3 (each within the scatter of the next).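

In this assay, among these compounds, a 9.2-fold lower number from compound 3 to compound 4 (0.96 log units; beyond the scatter) is the first single-place step, and it shows that chloro in place of hydrogen on this aromatic carbon, between two ring nitrogen atoms, moves the growth-inhibition number beyond the scatter. The earlier compounds shown here offered no such reading, as no pair among them differs in one place. No measurement shown here bears on the reason for this step.

Whether the step is specific to chloro stays open, as the compounds shown carry no other group at this position, such as an amine, a methoxy group or a fluoro group. Also open, on these data alone, is whether the same step would hold with the chloromethyl group placed as in compound 1 or compound 2.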